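The compounds below may be only part of what the source reports. "The series", "measured", "known", "first", "only" and "open" are said of these compounds alone.

Of the compounds shown here, two built on a shared core have been tested in a functional assay on HepG2 cells (Homo sapiens), read by MTT assay, with a stated time of 48 h; on this read-out higher numbers stand for weaker inhibition and lower numbers for stronger inhibition. Compound 1 `CCn1c(C(=O)NCCCN(C)C)ccc1C(CC)(CC)c1ccc(OCC(=O)C(C)(C)C)c(C)c1` gives 960 nM. For compound 2 `C#CCNC(=O)c1ccc(C(CC)(CC)c2ccc(OCC(O)C(C)(C)C)c(C)c2)n1CC` the result is only a limit, > 50000 nM, so its potency is not pinned to a number; the limit of > 50000 nM in this assay, at which 1 of the 2 values shown sits, shows where it stands. Compound 3 `CCn1c(C(=O)OCc2ccc(F)cc2)ccc1C(CC)(CC)c1ccc(OCC(O)C(C)(C)C)c(C)c1` is the next candidate, and it differs from compound 2 by (4-fluorobenzyl)oxy in place of propargylamino on a carbonyl carbon. Among the compounds with values here, no measured pair shows this exact change, so the step of an at least 5.0-fold lower number from compound 2 to compound 3 (0.69 log units; beyond the scatter) is an expectation toward stronger inhibition rather than a known result. Compound 3 is estimated at 10000 nM, plausibly between 2000 nM and 50000 nM.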

Compound 3, half-maximal inhibitory concentration: > 50000 nM
Compound 3 ended at the assay's limit (the forecaster's own chance of this, stated with the estimate: 35%); middle value at least 5.0-fold (0.69 log units) away from the limit.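

Within the data shown here, compound 2 and compound 3 both ended at a limit in this assay rather than at a number, so no step between them can be read. The compounds shown leave open whether (4-fluorobenzyl)oxy in place of propargylamino on a carbonyl carbon changes inhibition at all.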